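Thiosemicarbazone series: aryl change on the amide-type nitrogen

The source may hold more compounds than are shown below. What is called first, only, known or untested is meant among the compounds shown, and "the series" means these compounds.

Measured so far:
compound 1 `COc1cccc(NC(=S)N/N=C/c2ccc3ccccc3n2)c1` gives 74500 nM
compound 2 `CN(C)C(=S)N/N=C/c1ccc2ccccc2n1` gives 90 nM
compound 3 `NC(=S)N/N=C/c1nc2ccccc2s1` gives 5350 nM

All three numbers come from a functional assay on HeLa cells (Homo sapiens) for antiproliferative activity, read by sulforhodamine B assay, with a stated time of 72 h; a higher number here means a weaker inhibitor, a lower number a stronger inhibitor. Compound 1 holds the highest number of the three. Its nearest neighbour is compound 3, with a markedly lower number; compound 2 stands far lower still, so within this set compound 1 is the weakest inhibitor. Compound 2 carries two methyl groups on the amide-type nitrogen, whereas compound 1 carries an aryl group there; compound 3 has a different core and a bare nitrogen.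

Compound 4 `S=C(N/N=C/c1ccc2ccccc2n1)Nc1ccc(Cl)cc1` is not yet measured in this assay. Relative to compound 1 it differs as follows: 4-chlorophenyl in place of 3-methoxyphenyl on an amide-type nitrogen. The two aryl groups are of similar size and both sit on the amide-type nitrogen, so no large shift is expected from this change alone. The step of a 1.9-fold lower number from compound 1 to compound 4 (0.27 log units; within the scatter) is expected to be small, at most a modest move toward a lower number, and possibly none beyond the scatter. Compound 4 is estimated at 40000 nM, with a range of 10000 nM to 130000 nM.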

Compound 4, half-maximal inhibitory concentration: > 100000 nM
Compound 4 gave a limit, no number; the forecaster's own chance of this, stated with the estimate: 10%; middle value at least 2.5-fold (0.39 log units) from the limit.
By their numbers in this assay, from the lowest: compound 2; then compound 3; then compound 1. At a limit, above all of these: compound 4.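

In this assay compound 4 gives > 100000 nM, which is a limit and not a number. With 4-chlorophenyl in place of 3-methoxyphenyl on the amide-type nitrogen, the step reads an at least 1.3-fold higher number from compound 1 to compound 4 (0.12 log units; that floor lies within the scatter), so this change shows no move toward a lower number, while the true size of the step remains unread. This is the first pair in the series to differ in one place, and what it can show ends where the read-out stops: the limit of > 100000 nM in this assay, at which 1 of the 4 values shown sits.

Still open, as far as these compounds go, is whether an aryl group on this nitrogen can give a number beyond the scatter of compound 1 on the lower side, for example a phenyl ring bearing a carboxylic acid or an amine. Also open, from the compounds shown here alone, is how a longer chain in place of the aryl group would read on the shared core.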